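Compound 3 to compound 4: cytotoxicity on a shared core

This account rests on a few compounds, and the source may have more. Where it says the series, first, only, none or still open, it means among the compounds named here.

Compound 1, `Cc1ccc2[nH]c(=O)c(CN(Cc3ccc(OC(C)C)cc3)Cc3ccc(C(C)(C)C)cc3)cc2c1`: in a toxicity assay on MDCK cells (Canis lupus familiaris) for cytotoxicity, read by crystal violet staining, with a stated time of 48 h (a higher number here means that more compound is tolerated, a lower number that less compound is tolerated), compound 1 gives > 5000 nM, which is a limit of the assay rather than a number.
Compound 2, `CCCCOc1ccc(CN(Cc2ccc(C(C)(C)C)cc2)Cc2cc3cc(C)ccc3[nH]c2=O)cc1`: in this assay compound 2 gives > 5000 nM, again a limit.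
Compound 3, `Cc1ccc2[nH]c(=O)c(CN(Cc3ccc(C(C)(C)C)cc3)[C@H](CO)c3ccccc3)cc2c1`: in this assay compound 3 gives > 10000 nM, also a limit.

Compound 3 stands at the limit of > 10000 nM in this assay, at which 1 of the 3 values shown sits. The other two values sit at the limit of > 5000 nM in this assay, at which 2 of the 3 values shown sit. Every step between these three compounds is therefore unreadable: a step that the two limits leave unreadable from compound 1 to compound 2, a step that the two limits leave unreadable from compound 1 to compound 3 and a step that the two limits leave unreadable from compound 2 to compound 3. Among the measured compounds shown here, no measured step tells how large a change on the amine nitrogen can shift cytotoxicity here; all that is known is that none of the three compounds shows toxicity within the tested range.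

Compound 4 is `Cc1ccc2[nH]c(=O)c(CN(Cc3ccc(C(C)(C)C)cc3)[C@@H](C)c3ccc(F)cc3)cc2c1`. It differs from compound 3 in one place: 1-(4-fluorophenyl)ethyl in place of 2-hydroxy-1-phenylethyl on an amine nitrogen. The step that bears on it, from compound 3, is unreadable, so no direction can be drawn from the data. Compound 4 is expected to show a number no higher from compound 3 to compound 4 (the limit leaves the size open), no step beyond the scatter. Compound 4 is therefore estimated at 10000 nM in this assay, within a range of 5000 nM to 20000 nM, most likely again reported only as a limit.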

Compound 4, half-maximal cytotoxic concentration: > 5000 nM
Compound 4: only a limit was reported; the forecaster's own chance of this, stated with the estimate: 80%; the middle value is on the limit's open side.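

Compound 4 is reported only as a limit in this assay, as are compounds 1, 2 and 3, and the steps from those three to compound 4 cannot be read. The compounds shown leave open at what concentration any of them would harm the cells, and whether changes on the amine nitrogen shift that concentration at all.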